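One Halogen Swap Seen Twice in Growth Inhibition

The source may report more compounds than this note shows. Statements on the series, on what has been measured and on what is new or still open speak of the compounds shown alone.

Compound 1 `O=S(=O)(/C=C/c1ccc(Br)cc1)Cc1ccc(Nc2ncnc3ccccc23)cc1`: 55000 nM
Compound 2 `O=S(=O)(/C=C/c1ccc(Cl)cc1)Cc1ccc(Nc2ncnc3ccccc23)cc1`: > 100000 nM, a limit of the assay rather than a number
Compound 3 `O=S(=O)(/C=C/c1ccc(Br)cc1)Cc1ccc(Nc2ncnc3ccc(Br)cc23)cc1`: 3000 nM

All three were tested in a functional assay on DU-145 cells (Homo sapiens) for inhibition; a lower number here means a stronger inhibitor of growth, a higher number a weaker inhibitor of growth. Compound 1 gives 55000 nM there. Compound 2 reaches only the limit of the assay, (the limit of > 100000 nM in this assay, at which 1 of the 3 values shown sits). The step between them is an at least 1.8-fold higher number from compound 1 to compound 2 (0.25 log units; that floor lies within the scatter), and the change behind it is chloro in place of bromo on an aromatic carbon. Compound 3, with 3000 nM, differs from compound 1 in its core: bromo in place of hydrogen on an aromatic carbon; the step is an 18-fold lower number from compound 1 to compound 3 (1.26 log units; beyond the scatter).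

Compound 4 `O=S(=O)(/C=C/c1ccc(Cl)cc1)Cc1ccc(Nc2ncnc3ccc(Br)cc23)cc1` has not yet been measured. It differs from compound 3 in the same way that compound 2 differs from compound 1: chloro in place of bromo on an aromatic carbon. The two place lines agree word for word, so this is the same change on the other core.

Within the data shown here, the only guide for the step from compound 3 to compound 4 is the step from compound 1 to compound 2, which sits at a floor within the usual scatter, so compound 4 is expected to give a number close to compound 3 or somewhat higher. The expected step is a 2.3-fold higher number from compound 3 to compound 4 (0.37 log units; beyond the scatter), and the expected value for compound 4 in this assay is 7000 nM, with a likely range from 3000 nM to 20000 nM.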

Compound 4, concentration for 50% growth inhibition: 1000 nM
Compound 4: middle estimate off by 7.0-fold (0.85 log units), on the high side; measured number outside the range, below it.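

On the core that carries the extra bromo, chloro in place of bromo gives a 3.0-fold lower number from compound 3 to compound 4 (0.48 log units; beyond the scatter) in this assay, and this does not match the same change on the core of compound 1: the same change on two cores in this assay, an at least 1.8-fold higher number (0.25 log units; that floor lies within the scatter) from compound 1 to compound 2 and a 3.0-fold lower number (0.48 log units; beyond the scatter) from compound 3 to compound 4, at least 5.4-fold (0.73 log units) apart, beyond the scatter of two such steps

Bromo in place of hydrogen on the core gives an at least 100-fold lower number from compound 2 to compound 4 (2.00 log units; beyond the scatter), so the number falls with both side groups, but the two steps differ in size: the same change on two cores in this assay, an 18-fold lower number (1.26 log units; beyond the scatter) from compound 1 to compound 3 and an at least 100-fold lower number (2.00 log units; beyond the scatter) from compound 2 to compound 4, at least 5.4-fold (0.73 log units) apart, beyond the scatter of two such steps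

Among these compounds, compound 2 gives > 100000 nM, a limit of the assay and not a number, so the full size of its steps stays unknown, and with a single pair on each core the result shows only that the swap need not carry over unchanged, not how it would behave on any further core.

The compounds shown leave open whether a 4-fluorophenyl or 4-methoxyphenyl group in the same place would follow the pattern of compound 3 or that of compound 4. They also leave open whether a chloro, a nitrile or a methoxy group in place of the bromo on the core would lower the number as the bromo does.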